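Two inactive anilines and a 2-hydroxyphenyl variant

The compounds below may be only part of what the source reports. "The series", "measured", "known", "first", "only" and "open" are said of these compounds alone.

Measured compounds:
- Compound 1 `Fc1ccc(Nc2nc(-c3cccc(F)c3)nc3ccc(F)cc23)cc1`. In a functional assay on HL-60 cells (Homo sapiens) for cytotoxicity, read by MTT assay, with a stated time of 48 h (a higher number here means a weaker inhibitor, a lower number a stronger inhibitor), compound 1 reaches only the limit > 50000 nM.
- Compound 2 `Fc1cccc(-c2nc(Nc3cccc(Br)c3)c3cc(F)ccc3n2)c1`. In this assay compound 2 likewise reaches only the limit > 50000 nM.

Both measured values sit at the limit of this assay; (the limit of > 50000 nM in this assay, at which 2 of the 2 values shown sit). Compound 2 therefore stands at that limit, not at a number, and the step that the two limits leave unreadable from compound 1 to compound 2 cannot be read in either direction or size.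

The new compound 3 `Oc1ccccc1Nc1nc(-c2cccc(F)c2)nc2ccc(F)cc12` differs from compound 2 in one place: 2-hydroxyphenyl in place of 3-bromophenyl on a nitrogen on an aromatic ring. Among the compounds with values here, the only measured step, from compound 1 to compound 2, is unreadable, so no measured step gives the size or direction of an exchange at this nitrogen. Both measured compounds share the rest of the core with compound 3 and neither shows measurable inhibition in this assay.

With no readable step to build on, compound 3 is expected to stay near the limit, with an estimated step that the limit leaves unreadable from compound 2 to compound 3 from compound 2. For compound 3 the estimate in this assay is 60000 nM, expected within 15000 nM to 200000 nM, most likely reported again only as a limit.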

Compound 3, half-maximal inhibitory concentration: 44400 nM
Compound 3: middle estimate off by 1.4-fold (0.13 log units), on the high side, within the range that was stated.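

In this assay, within the data shown here, compound 3 gives the only value that is a number and not a limit, so a substituent on this nitrogen can now be tied to a reading. 2-Hydroxyphenyl in place of 3-bromophenyl gives an at least 1.1-fold lower number from compound 2 to compound 3 (0.05 log units; that floor lies within the scatter), and 2-hydroxyphenyl in place of 4-fluorophenyl gives an at least 1.1-fold lower number from compound 1 to compound 3 (0.05 log units; that floor lies within the scatter). Both steps are floors that lie within the scatter, so they show no effect of the exchange at this nitrogen, and the other two compounds offer no number to measure against: the limit of > 50000 nM in this assay, at which 2 of the 3 values shown sit.

Going by these compounds, the step between the two limit compounds cannot be read, and how far the steps to compound 3 really reach stays open. It is also open whether the hydroxyl itself matters, as the compounds shown include no methoxy group or amine in its place on that phenyl ring.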